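The source may hold more compounds than are shown below. What is called first, only, known or untested is meant among the compounds shown, and "the series" means these compounds.

Three compounds have been measured in a functional assay on M14 cells (Homo sapiens) for cytotoxicity, read by sulforhodamine B assay, with a stated time of 48 h; a higher number here means a weaker inhibitor of growth, a lower number a stronger inhibitor of growth:

compound 1 `ClCc1cccc(Cn2cnc3c(Cl)ncnc32)c1`, which gives 3310 nM;
compound 2 `ClCc1ccc(Cn2cnc3nc(Cl)nc(Cl)c32)cc1`, which gives 3160 nM;
compound 3 `ClCc1cccc(Cn2cnc3c(Cl)nc(Cl)nc32)c1`, which gives 3380 nM.

Compound 3 and compound 1 differ in one place: hydrogen in place of chloro on an aromatic carbon. In this assay this change made a step of a 1.0-fold lower number from compound 3 to compound 1 (0.01 log units; within the scatter), so the two numbers are indistinguishable. Compound 2 shares its atoms with compound 3 but joins them differently; the difference between the two cores is not broken down here, and their values in this assay show no separation.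

Compound 4 `ClCc1ccc(Cn2cnc3ncnc(Cl)c32)cc1` has not yet been measured. From compound 2 it differs as follows: hydrogen in place of chloro on an aromatic carbon. The surroundings of the changed carbon are described in the same words as for the step from compound 3 to compound 1, so this is the same change made on a different core. Because the earlier step was a 1.0-fold lower number from compound 3 to compound 1 (0.01 log units; within the scatter), the step from compound 2 to compound 4 in this assay is expected to be a 1.0-fold higher number from compound 2 to compound 4 (0.01 log units; within the scatter). On that basis compound 4 is estimated to give 3200 nM, with a likely range from 1600 nM to 6500 nM.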

Compound 4, concentration for total growth inhibition: 13200 nM
Compound 4: the middle estimate sits 4.1-fold (0.62 log units) below what was measured; measured number above the stated range.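

In this assay, hydrogen in place of chloro gave a 4.2-fold higher number from compound 2 to compound 4 (0.62 log units; beyond the scatter) and so a weaker inhibitor of growth, even though the changed carbon is described in the same words as the one changed on the other core. These two pairs do not show why the cores part, and they cannot say how the change would behave on a third core or which of the two results is the more usual. What they do show is that the size of this step did not carry from one core to the other: the same change on two cores in this assay, a 1.0-fold lower number (0.01 log units; within the scatter) from compound 3 to compound 1 and a 4.2-fold higher number (0.62 log units; beyond the scatter) from compound 2 to compound 4, 4.3-fold (0.63 log units) apart, beyond the scatter of two such steps

As far as these compounds go, both pairs replace chloro with hydrogen alone, so it remains open whether an amine or a methoxy group on that carbon would also give different results on the two cores. From the compounds shown here alone, it is equally open how either core would respond if the chloromethyl group on the benzene ring gave way to a longer chain or a carboxylic acid.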